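Carboxymethoxy Gives Way to a Boron Group, Twice

The source may report more compounds than this note shows. Statements on the series, on what has been measured and on what is new or still open speak of the compounds shown alone.

Measured so far in a functional assay on MCF-10A cells (Homo sapiens) for inhibition; a higher number here means a weaker inhibitor, a lower number a stronger inhibitor:
- compound 1 `O=C(O)COc1ccc(/C=C/C(=O)c2ccc(Cl)c(Cl)c2)cc1`: 12000 nM
- compound 2 `O=C(/C=C/c1ccc(B(O)O)cc1)c1ccc(Cl)c(Cl)c1`: 18000 nM
- compound 3 `O=C(O)COc1ccc(C(=O)/C=C/c2ccc(Cl)c(Cl)c2)cc1`: 13000 nM

Compound 1 and compound 3 are built from the same atoms joined differently; the difference between the two cores is not broken down here. Their values lie within the scatter of each other, so neither can be called the stronger. Compound 2 arises from compound 1 by one change, (a group of 3 heavy atoms (1 boron, 2 oxygen; no ring) in place of a group of 5 heavy atoms (2 carbon, 3 oxygen; no ring), on an aromatic carbon), and the step it made was a 1.5-fold higher number from compound 1 to compound 2 (0.18 log units; within the scatter).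

Compound 4 `O=C(/C=C/c1ccc(Cl)c(Cl)c1)c1ccc(B(O)O)cc1`, not yet measured in this assay, arises from compound 3 by the same change: a group of 3 heavy atoms (1 boron, 2 oxygen; no ring) in place of a group of 5 heavy atoms (2 carbon, 3 oxygen; no ring), on an aromatic carbon. The place is the same in both cases. Compound 4 is expected to show a step of a 1.5-fold higher number from compound 3 to compound 4 (0.16 log units; within the scatter), resting on the earlier step of a 1.5-fold higher number from compound 1 to compound 2 (0.18 log units; within the scatter), which stayed within the scatter. Compound 4 is therefore estimated at 19000 nM, between 9000 nM and 40000 nM.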

Compound 4, half-maximal inhibitory concentration: 18000 nM
Compound 4: the middle estimate sits 1.1-fold (0.02 log units) above what was measured; low and high end bracket the measured number.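

In this assay, putting the boron group in place of carboxymethoxy gave a 1.4-fold higher number from compound 3 to compound 4 (0.14 log units; within the scatter), so on this core too the step stayed within the scatter. Set beside the earlier step, the change carried over from one core to the other at much the same size: the same change on two cores in this assay, a 1.5-fold higher number (0.18 log units; within the scatter) from compound 1 to compound 2 and a 1.4-fold higher number (0.14 log units; within the scatter) from compound 3 to compound 4, 1.1-fold (0.03 log units) apart, within the scatter of two such steps This shows that the swap behaved alike on these two cores, but neither step separates the boron group from carboxymethoxy, and two cores cannot show how the change would behave on any other core.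

The compounds shown leave open how an amine or a nitrile on that same aromatic carbon would compare. They also leave open whether a longer chain there would give a step beyond the scatter.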